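The source may hold more compounds than are shown below. What is called first, only, known or untested is meant among the compounds shown, and "the series" means these compounds.

Measured so far:
compound 1, `Cc1cc(C)nc(N2CCN(c3ccn4c(CC(F)(F)F)cnc4c3C#N)CC2)n1`, gives 447 nM in a functional assay on CHO cells with metabotropic glutamate receptor 2 (Homo sapiens) as the target, read by GTPgammaS binding; a higher number here means that more compound is needed for the effect, a lower number that less compound is needed;
compound 2, `CCCc1cnc2c(C#N)c(N3CCN(c4nc(C)cc(C)n4)CC3)ccn12`, gives 646 nM in this assay.

In this assay compound 1 has the lowest of the two numbers, and the nearest number belongs to compound 2. Within the data shown here, the single step seen, a 1.4-fold higher number from compound 1 to compound 2 (0.16 log units; within the scatter), lies within the scatter. Compound 3, `N#Cc1c(N2CCN(c3ncccn3)CC2)ccn2c(CC(F)(F)F)cnc12`, differs from compound 1 in one place: pyrimidin-2-yl in place of 4,6-dimethylpyrimidin-2-yl on an amine nitrogen in a ring. Among the measured compounds shown here, no measured step touches this position, and the one step known concerns another group, so nothing argues for a change beyond the scatter. The expected step is a 1.6-fold higher number from compound 1 to compound 3 (0.19 log units; within the scatter). Compound 3 is estimated at 700 nM, with a range from 250 nM to 2500 nM.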

Compound 3, half-maximal effective concentration: 851 nM
For compound 3 the middle estimate is 1.2-fold (0.08 log units) below the measured one, within the range that was stated.
By their numbers in this assay, from the lowest: compounds 1, 2 and 3 (each within the scatter of the next).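

In this assay, the first change measured on this amine nitrogen in a ring gives a 1.9-fold higher number from compound 1 to compound 3 (0.28 log units; within the scatter), so the compounds shown do not separate pyrimidin-2-yl from 4,6-dimethylpyrimidin-2-yl here. With the rest of compound 1 unchanged, the two methyl groups on the pyrimidine make no difference beyond the scatter. No independent evidence bears on this result. From the compounds shown here alone, it remains open whether a phenyl ring, a pyridin-2-yl group or an acetyl group on this nitrogen would stay within the scatter. Going by these compounds, it is also open whether the same step would hold with the chain of compound 2.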